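From Carboxy to Sulfamoyl in a Cell Toxicity Test

A few compounds are considered here, and "the series" means these few. Any claim that something is new, unique, unknown or untested is made for them only; others in the source may bear on it.

In an ADME assay on Vero cells (Chlorocebus sabaeus) for cytotoxicity, read by MTT assay, with a stated time of 72 h (a lower number here means a stronger inhibitor, a higher number a weaker inhibitor), compound 1 `COc1ccc(-c2ccnc(Nc3ccc(C(=O)O)cc3)n2)cc1` gives > 100000 nM as its reading, and that reading is a limit of the assay and not a number. Compound 2 `COc1ccc(-c2ccnc(Nc3cccc(C(N)=O)c3)n2)cc1` gives 2700 nM in this assay as an actual measured number.

Compound 3 `COc1ccc(-c2ccnc(Nc3ccc(S(N)(=O)=O)cc3)n2)cc1` has not been measured yet. It differs from compound 1 in one place: sulfamoyl in place of carboxy on an aromatic carbon sums up the swap, with sulfamoyl in place of carboxy on an aromatic carbon, para to a large group.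

Going by the values given here, no measured pair of compounds shows what this swap does, so any expectation here is rough. Compound 2 at 2700 nM shows that a compound of this set can give a real number in this assay. Compound 3 is therefore expected to read lower than compound 1, which would mean a stronger inhibitor, by a step beyond the usual scatter. The expected change is an at least 4.0-fold lower number from compound 1 to compound 3 (0.60 log units; beyond the scatter) in size and direction. For compound 3 the estimated value is 25000 nM with an expected range from 6000 nM up to 100000 nM. There is a real chance that compound 3 will also give only a limit.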

Compound 3, half-maximal inhibitory concentration: 2400 nM
Compound 3: the middle estimate sits 10-fold (1.02 log units) above what was measured; the measured number lies below the stated range.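

In this assay compound 1, with carboxy on an aromatic carbon para to a large group, gives > 100000 nM as its reading, and that reading is a limit of the assay and not a number. Putting sulfamoyl at that same place, with the rest of the molecule unchanged, brings the reading down to a real number (a step of an at least 41-fold lower number from compound 1 to compound 3 (1.61 log units; beyond the scatter)), so this single position clearly matters in this test, and exchanging one group there is enough to move a compound from a limit to a measured value of cell toxicity. The step gives only the smallest possible size of the change and not its full size, because one end of it rests on a limit: the limit of > 100000 nM in this assay, at which 1 of the 3 values shown sits.

Going by these compounds, with a single pair, it stays open whether the lower reading belongs to sulfamoyl in particular or would follow from other replacements of carboxy at this place, such as an amine or a nitrile. Going by these compounds alone, it also stays open whether the same swap would have a similar effect on a core other than the one shared by compound 1 and compound 3.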